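Trifluoromethoxy Replaces Fluoro on a Non-Cytotoxic Scaffold

The source may report more compounds than this note shows. Statements on the series, on what has been measured and on what is new or still open speak of the compounds shown alone.

The series is built on the core shared by compound 1 `COc1ccc(-c2nc3c(c(C)nn3-c3ccccc3)c(-c3ccccc3O)c2C#N)cc1` and compound 2 `CCc1ccc(-c2nc3c(c(C)nn3-c3ccccc3)c(-c3ccccc3F)c2C#N)cc1`. In an ADME assay on BJ cells (Homo sapiens) for cytotoxicity, with a stated time of 72 h (a higher number here means that more compound is needed for the effect, a lower number that less compound is needed), compound 1 gives only a limit of the assay, > 23000 nM. Compound 2 also gives only a limit in this assay, namely > 20000 nM. Both readings, the limit of > 20000 nM in this assay, at which 1 of the 2 values shown sits, and (the limit of > 23000 nM in this assay, at which 1 of the 2 values shown sits), are limits rather than numbers, so neither compound shows a measurable effect in the tested range and the two cannot be ordered against each other.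

Compound 3 `CCc1ccc(-c2nc3c(c(C)nn3-c3ccccc3)c(-c3ccccc3OC(F)(F)F)c2C#N)cc1` differs from compound 2 in one place, (trifluoromethoxy in place of fluoro on an aromatic carbon), on an aromatic carbon ortho to a large group. Among the compounds with values here, no step between measured compounds exists, and both measured values are limits, so no step beyond the scatter is expected in this assay. For compound 3 the expected step is a step that the limit leaves unreadable from compound 2 to compound 3. Compound 3 is estimated at 25000 nM in this assay, probably again a limit, within 10000 nM to 60000 nM.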

Compound 3, half-maximal effective concentration: > 20000 nM
Compound 3: a limit, no number; the forecaster's own chance of this, stated with the estimate: 80%; the middle value is on the limit's open side.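

Within the data shown here, compound 3, like compound 2, gives only a limit in this assay, so no step from compound 2 to compound 3 can be read. The compounds shown leave open at what concentration any of them would reach a half-maximal effect, and whether trifluoromethoxy and fluoro would then differ.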